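Nitro in Place of Methoxy: Vero Cell Cytotoxicity Compared

This account rests on a few compounds, and the source may have more. Where it says the series, first, only, none or still open, it means among the compounds named here.

Compound 1 `COc1ccc(C2SCC(=O)N2CCN2CCCCC2)cc1` gives 73% in an ADME assay on Vero cells (Chlorocebus sabaeus) for cytotoxicity, read by neutral red uptake, tested at 394 ug/mL; a lower number here means a stronger effect, a higher number a weaker effect of the compound at the concentration tested.
Compound 2 `O=C1CSC(c2ccc([N+](=O)[O-])cc2)N1CCN1CCCCC1` gives 66% in this assay.
Compound 3 `COc1ccccc1C1SCC(=O)N1CCN1CCCCC1` gives 67% in this assay.

Compound 4 `O=C1CSC(c2ccccc2[N+](=O)[O-])N1CCN1CCCCC1` has not yet been measured in this assay. Compound 3 and compound 1 are built from the same atoms joined differently, and the difference between the two cores is not broken down here. From compound 1 to compound 2 the change is nitro in place of methoxy on an aromatic carbon, and it gave a number 7 percentage points lower from compound 1 to compound 2 (within the scatter). From compound 3 to compound 4 the change is nitro in place of methoxy on an aromatic carbon. The two changes are of the same kind, but in one the nitro stands para to a large group and in the other ortho to a large group, so they are not the same change. Compound 2 and compound 3 lie within the scatter of each other. The expectation for compound 4 rests on the measured step from compound 1 to compound 2 alone. The estimated step for compound 4 is a number 7 percentage points lower from compound 3 to compound 4 (within the scatter). Compound 4 is therefore expected to give about 60%, most likely between 46% and 74%.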

Compound 4, a percentage reported as activity, at one concentration (the size of the read-out at that concentration, not a potency): 100%
Compound 4: the middle estimate sits 40 percentage points below what was measured, outside the stated range (above it).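

In this assay, nitro in place of methoxy on an aromatic carbon, here ortho to a large group, gave a number 33 percentage points higher from compound 3 to compound 4 (beyond the scatter). Set beside the earlier step, this shows that the change did not carry over from one core to the other, so a step read on one of these cores gave no safe guide to the same change on the other: the same change on two cores in this assay, a number 7 percentage points lower (within the scatter) from compound 1 to compound 2 and a number 33 percentage points higher (beyond the scatter) from compound 3 to compound 4, 40 percentage points apart, beyond the scatter of two such steps. Within the data shown here, it does not show why the two steps part, whether the place of the nitro is what separates them, or how the change would behave on any further core, as only two such pairs are at hand.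

The compounds shown leave open whether a nitrile, a carboxylic acid or an amine in place of methoxy would also give steps that differ from core to core. They also leave open whether a longer chain in place of the one shared by all four compounds would alter either step.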